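A few compounds are considered here, and "the series" means these few. Any claim that something is new, unique, unknown or untested is made for them only; others in the source may bear on it.

Measured compounds in a functional assay on HCT-15 cells (Homo sapiens) for inhibition, read by sulforhodamine B assay, with a stated time of 48 h; a higher number here means a weaker inhibitor of growth, a lower number a stronger inhibitor of growth:
compound 1 `CC(=O)/C(=C\c1c(-c2ccccc2)[nH]c2ccccc12)S(=O)(=O)c1ccccc1` gives 836 nM
compound 2 `COc1ccc(-c2[nH]c3ccccc3c2/C=C(\C#N)S(=O)(=O)c2ccccc2)cc1` gives 554 nM
compound 3 `COc1ccc2[nH]c(-c3ccccc3)c(/C=C(\C#N)S(=O)(=O)c3ccccc3)c2c1` gives 4000 nM

Compound 3 stands at the highest number of the three in this assay. Its nearest neighbour is compound 1, whose number is well below and the gap is beyond the scatter of repeated runs; compound 2 lies further still, also beyond the scatter. Among the compounds with values here, no pair among the three differs in only one place, so the three numbers are read singly and no measured step is available for the change now considered.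

Compound 4 `N#C/C(=C\c1c(-c2ccccc2)[nH]c2ccccc12)S(=O)(=O)c1ccccc1` has not yet been measured. It arises from compound 3 by hydrogen in place of methoxy on an aromatic carbon. Beyond that, compound 4 shares the nitrile-bearing arm of compounds 2 and 3 and carries no substituent on the shared core, as compound 1 does not.

Since both compounds without a methoxy on the core, compound 1 and compound 2, sit well below compound 3, the expectation for compound 4 is a clear fall in number, beyond the scatter, as the step of a 5.7-fold lower number from compound 3 to compound 4 (0.76 log units; beyond the scatter) states. Compound 4 is expected to come in around 700 nM, with a plausible range from 300 nM to 1600 nM. The direction rests on two compounds only and remains to be tested.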

Compound 4, concentration for 50% growth inhibition: 1100 nM
Beside the measured number, compound 4's estimate is 1.6-fold (0.20 log units) below it; the range from low to high includes it.
By their numbers in this assay, from the lowest: compounds 2, 1 and 4 (each within the scatter of the next); then compound 3.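

Within the data shown here, removing the methoxy from the shared core gives a 3.6-fold lower number from compound 3 to compound 4 (0.56 log units; beyond the scatter) in this assay and is the first single change measured at this position, tying the high number of compound 3 to that methoxy on the core. The same exchange at the methoxy of compound 2, which sits on the other aromatic ring rather than on the shared core, gives a 2.0-fold higher number from compound 2 to compound 4 (0.30 log units; within the scatter) and stays within the scatter, so the two methoxy placements do not read alike in this small set. With the methoxy absent from the core, cyano in place of acetyl gives a 1.3-fold higher number from compound 1 to compound 4 (0.12 log units; within the scatter) and also stays within the scatter, so the arm exchange shows no measurable effect on this core.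

No measurement bearing on why the core methoxy raises the number is at hand. Open questions are whether a hydroxyl, a fluorine or an amine at the same aromatic carbon would behave as the methoxy does, and whether the methoxy step would recur on the core of compound 1 with the acetyl arm in place.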